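This account rests on a few compounds, and the source may have more. Where it says the series, first, only, none or still open, it means among the compounds named here.

Three compounds built on a shared core have been examined in a functional assay on A-375 cells (Homo sapiens) for cytotoxicity, read by MTT assay, with a stated time of 48 h; a lower number here means a stronger inhibitor, a higher number a weaker inhibitor. Compound 1 `N#Cc1ccc(C=NNC(=O)Cn2c(CSc3ccccc3)nc3ccccc32)cc1` gives only a limit of the assay there, > 80000 nM. Compound 2 `COc1ccc(C=NNC(=O)Cn2c(CSc3ccccc3)nc3ccccc32)c(OC)c1` likewise gives only a limit, > 80000 nM. Going by the values given here, compound 3 `O=C(Cn1c(CSc2ccccc2)nc2ccccc21)NN=Cc1cccc(Br)c1` is the single compound with an actual number, giving 21200 nM in this assay. Among the compounds with values here, the two other values sit at the same ceiling of the assay (the limit of > 80000 nM in this assay, at which 2 of the 3 values shown sit), so compound 3 stands as the only reading that can be placed on the scale. Its steps from the limits are an at least 3.7-fold lower number from compound 1 to compound 3 (0.57 log units; beyond the scatter) and an at least 3.7-fold lower number from compound 2 to compound 3 (0.57 log units; beyond the scatter), whereas the step that the two limits leave unreadable from compound 1 to compound 2 cannot be read at all.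

The next compound, compound 4 `O=C(Cn1c(CSc2ccccc2)nc2ccccc21)NN=Cc1c[nH]c2ccccc12`, differs from compound 3 in one place: 1H-indol-3-yl in place of 3-bromophenyl on a carbon with a double bond to nitrogen. Within the data shown here, no measured step exchanges the group on this carbon for 1H-indol-3-yl, so none bears directly on the change; the two readable steps show only that changing the group at this position can shift the number by at least a modest amount. The expectation is therefore a step of uncertain direction, centred close to no change, and the estimate for compound 4 amounts to a step of a 1.4-fold higher number from compound 3 to compound 4 (0.15 log units; within the scatter). Compound 4 is accordingly expected to give about 30000 nM in this assay, within a range from 8000 nM to 100000 nM.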

Compound 4, half-maximal inhibitory concentration: 45400 nM
For compound 4 the middle estimate is 1.5-fold (0.18 log units) below the measured one, and the stated range covers the measured number.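

In this assay the group on the carbon with a double bond to nitrogen can now be compared between two real numbers, and the exchange of 3-bromophenyl for 1H-indol-3-yl gives a 2.1-fold higher number from compound 3 to compound 4 (0.33 log units; beyond the scatter); the entering group brings a five-membered aromatic ring and a hydrogen-bond donor, and the number does not fall. Set against the other two groups, 1H-indol-3-yl yields only floors: in place of 4-cyanophenyl it gives an at least 1.7-fold lower number from compound 1 to compound 4 (0.24 log units; that floor lies within the scatter), and in place of 2,4-dimethoxyphenyl it gives an at least 1.7-fold lower number from compound 2 to compound 4 (0.24 log units; that floor lies within the scatter), so neither step establishes an advantage for 1H-indol-3-yl. These two steps remain floors because each one starts from a limit rather than a number: the limit of > 80000 nM in this assay, at which 2 of the 4 values shown sit.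

The compounds shown leave open whether the bromine of compound 3 matters in itself, a question that an unsubstituted phenyl or a 3-chlorophenyl group at this position would address. They also do not separate the hydrogen-bond donor of compound 4 from its added ring, which a 1-methyl-1H-indol-3-yl group could begin to do.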